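The source may hold more compounds than are shown below. What is called first, only, known or untested is meant among the compounds shown, and "the series" means these compounds.

Compound 2 `Cc1ccnc(-c2cnc(C(=O)CCCCCCc3ccccc3)o2)c1` gives 2000 nM in an assay on isolated protein for inhibition of liver carboxylesterase 1 (Homo sapiens) (on this read-out lower numbers stand for stronger inhibition and higher numbers for weaker inhibition), and stands level with compound 3 `O=C(CCCCCCc1ccccc1)c1ncc(-c2cc(C(F)(F)F)ccn2)o1`, which gives 2000 nM; the step of no change at the digits printed from compound 2 to compound 3 (within the scatter). Compound 1 `NC(=O)c1cccc(-c2cnc(C(=O)CCCCCCc3ccccc3)o2)c1` gives only a limit of this assay, > 100000 nM. The step of an at least 50-fold lower number from compound 1 to compound 2 (1.69 log units; beyond the scatter), a change of the group on the same aromatic carbon that compound 4 now alters. Compound 4 `O=C(CCCCCCc1ccccc1)c1ncc(-c2cc(=O)[nH]c(=O)[nH]2)o1` carries a group of 8 heavy atoms (4 carbon, 2 nitrogen, 2 oxygen; one six-membered aromatic ring with 2 hetero atoms) in place of a group of 7 heavy atoms (6 carbon, 1 nitrogen; one six-membered aromatic ring with 1 hetero atom), on an aromatic carbon. Going by the values given here, of the measured steps, only the one from compound 1 to compound 2 bears on this change, and it was large; the entering group, with two hydrogen-bond donors, is closer in character to the departed carbamoylphenyl than to the pyridyl. A large step toward weaker inhibition is therefore expected, a 15-fold higher number from compound 2 to compound 4 (1.18 log units; beyond the scatter), and compound 4 is estimated at 30000 nM, between 5000 nM and 100000 nM.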

Compound 4, half-maximal inhibitory concentration: 30000 nM
Compound 4: the middle estimate sits on the measured number at the digits printed, within the range that was stated.
By their numbers in this assay, from the lowest: compounds 2 and 3 (each within the scatter of the next); then compound 4. At a limit, above all of these: compound 1.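

In this assay, the carbon next to the ring oxygen now has a measured penalty, not just a limit, for a replacement of the 4-methylpyridin-2-yl group: a 15-fold higher number from compound 2 to compound 4 (1.18 log units; beyond the scatter). Yet this group is not as poor as 3-carbamoylphenyl, with an at least 3.3-fold lower number from compound 1 to compound 4 (0.52 log units; beyond the scatter). That comparison has only one end fixed, as compound 1 stands at a limit: the limit of > 100000 nM in this assay, at which 1 of the 4 values shown sits.

The compounds shown leave open whether a ring with 2 hetero atoms alone costs this much. A pyrimidine carrying methyl, or an aminopyridine, at this carbon would separate the ring from its carbonyls and hydrogen-bond donors.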